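Working notes: swapping the chain-end amine of compound 2

The source may report more compounds than this note shows. Statements on the series, on what has been measured and on what is new or still open speak of the compounds shown alone.

Compound 2 `COc1cc2c(Nc3ccc(C#N)cc3)ncnc2cc1OCCCN1CCC(N(C)C)CC1` gives 28300 nM in a functional assay on DU-145 cells (Homo sapiens) for antiproliferative activity, read by MTT assay, with a stated time of 72 h (a lower number here means a stronger inhibitor, a higher number a weaker inhibitor), and sits at the low end of the two numbers shown, within the scatter of compound 1 `COc1cc2c(Nc3ccc(C#N)cc3)ncnc2cc1OCCCN(C)C`, which in this assay gives 35300 nM. The step of a 1.2-fold lower number from compound 1 to compound 2 (0.10 log units; within the scatter) is within the scatter. Compound 3 `COc1cc2c(Nc3ccc(C#N)cc3)ncnc2cc1OCCCN1CCN(c2ccncc2)CC1` differs from compound 2 by 4-(pyridin-4-yl)piperazin-1-yl in place of 4-(dimethylamino)piperidin-1-yl on a saturated chain carbon, three bonds along the chain from an oxygen on an aromatic ring. Among the compounds with values here, the one step bearing on this place, a 1.2-fold lower number from compound 1 to compound 2 (0.10 log units; within the scatter), did not move the number, so no step beyond the scatter is expected in this assay in either direction. Compound 3 is therefore estimated at 26000 nM, range 9000 nM to 75000 nM. The expected step is a 1.1-fold lower number from compound 2 to compound 3 (0.04 log units; within the scatter).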

Compound 3, half-maximal inhibitory concentration: 22900 nM
Estimate against measurement, compound 3: 1.1-fold (0.06 log units) above; low and high end bracket the measured number.
By their numbers in this assay, from the lowest: compounds 3, 2 and 1 (each within the scatter of the next).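

Adding an aromatic ring at the chain end, as 4-(pyridin-4-yl)piperazin-1-yl, gives a 1.2-fold lower number from compound 2 to compound 3 (0.09 log units; within the scatter) in this assay, so this larger group also leaves the number unmoved. Against dimethylamino the result is a 1.5-fold lower number from compound 1 to compound 3 (0.19 log units; within the scatter), which places all three chain-end groups shown within the scatter of one another. No measurement shown here accounts for this flat response.

Going by these compounds, whether a carboxylic acid or a primary amine at the chain end would shift the number remains open. So does the effect of a longer chain.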